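This account rests on a few compounds, and the source may have more. Where it says the series, first, only, none or still open, it means among the compounds named here.

Measured so far:
Compound 1, `CC(C)n1nc(-c2cccnc2)c2ccccc2c1=O`: 3090 nM in a functional assay (trachea) with Cavia porcellus as the target; on this read-out lower numbers stand for stronger inhibition and higher numbers for weaker inhibition
Compound 2, `CC(=O)OCCn1nc(-c2cccnc2)c2ccccc2c1=O`: 9770 nM
Compound 3, `CCOC(=O)CCCn1nc(-c2cccnc2)c2ccccc2c1=O`: 10000 nM

Compound 3 shows the highest number of the three, though the gap to compound 2 is within the scatter; compound 1 sits clearly lower, with a 3.2-fold higher number from compound 1 to compound 3 (0.51 log units; beyond the scatter) and a 3.2-fold higher number from compound 1 to compound 2 (0.50 log units; beyond the scatter). Compound 4, `NCCn1nc(-c2cccnc2)c2ccccc2c1=O`, is not yet measured. It differs from compound 3 as follows: amino in place of (ethoxycarbonyl)methyl on a saturated chain carbon, two bonds along the chain from an aromatic nitrogen. Going by the values given here, no measured step exchanges this part for an amino group, so only indirect guidance exists: the step of a 1.0-fold higher number from compound 2 to compound 3 (0.01 log units; within the scatter) shows that swapping one chain end for another left the number essentially unchanged. A step of similar size, within the scatter, is therefore expected: a 1.4-fold lower number from compound 3 to compound 4 (0.15 log units; within the scatter). Compound 4 is estimated at 7000 nM, with a range from 2500 nM to 20000 nM.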

Compound 4, half-maximal inhibitory concentration: > 100000 nM
Compound 4: a limit, no number; the forecaster's own chance of this, stated with the estimate: 15%; middle value at least 14-fold (1.15 log units) from the limit.
By their numbers in this assay, from the lowest: compound 1; then compounds 2 and 3 (each within the scatter of the next). At a limit, above all of these: compound 4.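

Compound 4 stands at a limit of the assay, not at a number: the limit of > 100000 nM in this assay, at which 1 of the 4 values shown sits. The isopropyl and ester-bearing chains had differed only modestly, but the amino end brings much weaker inhibition: an at least 10-fold higher number from compound 3 to compound 4 (1.00 log units; beyond the scatter), an at least 10-fold higher number from compound 2 to compound 4 (1.01 log units; beyond the scatter) and an at least 32-fold higher number from compound 1 to compound 4 (1.51 log units; beyond the scatter). So this position is not indifferent to what the chain carries, which the earlier compounds did not show.

Going by these compounds, it remains open whether the amino group itself or the short 2-aminoethyl chain matters more. A longer chain ending in an amine, or a chain ending in a carboxylic acid, would help separate the two.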